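Aryl swap on the amide-type ring nitrogen: clearance notes

This account rests on a few compounds, and the source may have more. Where it says the series, first, only, none or still open, it means among the compounds named here.

Measured so far in an ADME assay on microsomes from liver (Mus musculus) for metabolic stability, read by LC-MS, using NADPH, with a stated time of 10 min, tested at 0.1 uM; on this read-out higher numbers stand for fast clearance and lower numbers for slow clearance:
- compound 1 `O=C(NCCCCc1ccccc1)c1cccc(C2SCC(=O)N2c2cccc(-c3c[nH]nn3)c2)c1`: 951 mL.min-1.g-1
- compound 2 `O=C(NCCCCc1ccccc1)c1cccc(C2SCC(=O)N2c2cccc(F)c2)c1`: 2740 mL.min-1.g-1
- compound 3 `O=C(NCCCCc1ccccc1)c1cccc(C2SCC(=O)N2c2ccc(C3CC3)cc2)c1`: 2960 mL.min-1.g-1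

Compound 3 has the highest of the three numbers, but only the gap to compound 1 is beyond the scatter: a 3.1-fold higher number from compound 1 to compound 3 (0.49 log units; beyond the scatter). The fluoro analogue shows the same kind of gap to compound 1: a 2.9-fold higher number from compound 1 to compound 2 (0.46 log units; beyond the scatter). Between compound 2 and compound 3 there is no real difference: a 1.1-fold higher number from compound 2 to compound 3 (0.03 log units; within the scatter).

Compound 4 `COc1ccc(F)cc1N1C(=O)CSC1c1cccc(C(=O)NCCCCc2ccccc2)c1` carries 5-fluoro-2-methoxyphenyl in place of 4-cyclopropylphenyl on an amide-type nitrogen in a ring. Going by the values given here, the step that bears on this is the one from compound 2 to compound 3, where one aryl group on the amide-type nitrogen in a ring was exchanged for another and the number stayed within the scatter. The steps involving compound 1 were larger, but both concern the 1H-1,2,3-triazol-4-yl, which compound 4 does not carry. Among the compounds with values here, no measured compound carries the 5-fluoro-2-methoxyphenyl group, so nothing here points to a shift in either direction.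

Compound 4 is therefore expected to give a number close to compound 3, with a step of a 1.2-fold lower number from compound 3 to compound 4 (0.07 log units; within the scatter) expected to stay within the scatter. The estimate for compound 4 is 2500 mL.min-1.g-1, with a range from 1100 mL.min-1.g-1 to 5500 mL.min-1.g-1.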

Compound 4, intrinsic clearance in microsomes in the Mus musculus assay: 2250 mL.min-1.g-1
Compound 4: the middle estimate sits 1.1-fold (0.05 log units) above what was measured; the range from low to high includes it.
By their numbers in the Mus musculus assay, from the lowest: compound 1; then compounds 4, 2 and 3 (each within the scatter of the next).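

On the amide-type nitrogen in a ring, 5-fluoro-2-methoxyphenyl leaves the Mus musculus assay level with the other two simple aryl groups, with a 1.3-fold lower number from compound 3 to compound 4 (0.12 log units; within the scatter) and a 1.2-fold lower number from compound 2 to compound 4 (0.09 log units; within the scatter), while the 1H-1,2,3-triazol-4-yl compound stays apart, with a 2.4-fold higher number from compound 1 to compound 4 (0.37 log units; beyond the scatter). In a physicochemical assay for solubility, read by turbidimetry, measured as kinetic solubility, at pH 6.8 (a lower number here means a less soluble compound, a higher number a more soluble compound), compound 3 gives 2000 nM and compound 4 gives 10000 nM. The exchange of 4-cyclopropylphenyl for 5-fluoro-2-methoxyphenyl therefore raises solubility at this position, although clearance stays within the scatter: the measured solubility of compound 3, 2000 nM, and of compound 4, 10000 nM, a 5.0-fold higher number (0.70 log units; beyond the scatter)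

The compounds shown do not separate the share of the methoxy from that of the fluoro in this solubility step. On these data alone, whether an amine or a carboxylic acid on this aryl group would match the clearance of compound 1 also remains open.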